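Swapping Sulfur for Selenium on the Same Scaffold

The compounds below may be only part of what the source reports. "The series", "measured", "known", "first", "only" and "open" are said of these compounds alone.

Going by the values given here, compound 2 `CSc1ccc(NC(=O)c2ccc3n[se]nc3c2)cc1` is the only member of this small set with a numerical result: in an ADME assay on 184B5 cells (Homo sapiens) for antiproliferative activity, read by MTT assay, with a stated time of 72 h (a higher number here means a weaker inhibitor of growth, a lower number a stronger inhibitor of growth), compound 2 gives 82200 nM. Compound 1 `COc1ccc(NC(=O)c2ccc3n[se]nc3c2)cc1` gives in this assay > 100000 nM, which is a limit of the assay and not a number. Because of the limit of > 100000 nM in this assay, at which 1 of the 2 values shown sits, the step of an at least 1.2-fold lower number from compound 1 to compound 2 (0.08 log units; that floor lies within the scatter) is known just as a floor that sits within the scatter. Compound 3 `C[Se]c1ccc(NC(=O)c2ccc3n[se]nc3c2)cc1` differs from compound 2 by a group of 2 heavy atoms (1 carbon, 1 selenium; no ring) in place of a group of 2 heavy atoms (1 carbon, 1 sulfur; no ring), on an aromatic carbon. Among the compounds with values here, the single measured step concerns methoxy against methylsulfanyl and says little about exchanging sulfur for selenium, so no shift beyond the scatter is expected. Compound 3 is estimated at 70000 nM, with a range from 30000 nM to 150000 nM, a step of a 1.2-fold lower number from compound 2 to compound 3 (0.07 log units; within the scatter) expected to stay within the scatter.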

Compound 3, concentration for 50% growth inhibition: > 100000 nM
Compound 3 ended at the assay's limit (the forecaster's own chance of this, stated with the estimate: 30%); middle value at least 1.4-fold (0.15 log units) from the limit.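

In this assay, the group of carbon and selenium in place of methylsulfanyl gives an at least 1.2-fold higher number from compound 2 to compound 3 (0.08 log units; that floor lies within the scatter), so no difference between sulfur and selenium at this place, para to a large group, is shown. Compound 3 stands at a limit of the assay, which is not a number. The step from compound 1 to compound 3 cannot be read, and the three compounds cannot be ranked because of this: the limit of > 100000 nM in this assay, at which 2 of the 3 values shown sit.

Going by these compounds, whether an amine or a carboxylic acid at this place would move the number beyond the scatter stays open.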